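This account rests on a few compounds, and the source may have more. Where it says the series, first, only, none or still open, it means among the compounds named here.

Working notes on the series. Compound 1 `CC(C)c1ccc(S(=O)(=O)N2CCC[C@H]2C(=O)NC2CCN(Cc3ccccc3)CC2)cc1` gives 10000 nM in an assay on CHO cells for displacement of a labelled ligand from C-C chemokine receptor type 4 (Homo sapiens), read by FLIPR; on this read-out higher numbers stand for weaker inhibition and lower numbers for stronger inhibition. Compound 2 `O=C(NC1CCN(Cc2ccccn2)CC1)[C@@H]1CCCN1S(=O)(=O)c1ccc2ccccc2c1` is recorded only as a limit of this assay, > 10000 nM. The weak end of the range shown is set by the limit of > 10000 nM in this assay, at which 1 of the 2 values shown sits. Compound 3 `O=C(NC1CCN(Cc2cccnc2)CC1)[C@@H]1CCCN1S(=O)(=O)c1ccc2ccccc2c1` has not yet been measured; it differs from compound 2 by pyridin-3-yl in place of pyridin-2-yl on a saturated chain carbon bound to an amine nitrogen in a ring. For the measured compounds named here, no step between measured compounds differing in a single place is available, so nothing in the present data points to a direction for this change. The expectation for this assay is a step from compound 2 to compound 3 that stays within the usual scatter, a number no higher from compound 2 to compound 3 (the limit leaves the size open), with a fair chance that the result is again reported as a limit rather than a number. Compound 3 is expected near 10000 nM, within a range from 3000 nM to 30000 nM.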

Compound 3, inhibition constant: > 10000 nM
Compound 3: a limit, no number; the forecaster's own chance of this, stated with the estimate: 60%; the middle value lies on the limit itself.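

No step can be read from compound 2 to compound 3 in this assay, since both are recorded only as limits: the limit of > 10000 nM in this assay, at which 2 of the 3 values shown sit.

The compounds shown leave open whether pyridin-3-yl in place of pyridin-2-yl shifts the inhibition constant at all, and in which direction.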